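Three Limits and a Fourth Aryl Group

This account rests on a few compounds, and the source may have more. Where it says the series, first, only, none or still open, it means among the compounds named here.

Compound 1 `N#CC1=C(N)Oc2c(N)cc3nc4ccccc4nc3c2C12C(=O)N(Cc1cnnn1-c1ccc(Cl)cc1)c1ccccc12` gives > 50000 nM in an ADME assay on L02 cells (Homo sapiens) for antiproliferative activity, read by MTT assay, with a stated time of 48 h (on this read-out lower numbers stand for stronger inhibition and higher numbers for weaker inhibition), which is a limit of the assay and not a number.
Compound 2 `N#CC1=C(N)Oc2c(N)cc3nc4ccccc4nc3c2C12C(=O)N(Cc1cnnn1-c1ccc([N+](=O)[O-])cc1)c1ccccc12` gives > 50000 nM in this assay, again a limit.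
Compound 3 `N#CC1=C(N)Oc2c(N)cc3nc4ccccc4nc3c2C12C(=O)N(Cc1cnnn1-c1ccc(Cl)cc1Cl)c1ccccc12` gives > 50000 nM in this assay, again a limit.

All three measured compounds share one core and differ only in the aryl group on the triazole nitrogen. Compound 3 stands where the other two stand: at the limit of > 50000 nM in this assay, at which 3 of the 3 values shown sit, so no ordering among them can be read. The step that the two limits leave unreadable from compound 1 to compound 2 is unreadable, as is a step that the two limits leave unreadable from compound 1 to compound 3 and a step that the two limits leave unreadable from compound 2 to compound 3; none of them shows whether changing this aryl group moves the read-out at all.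

Compound 4 `Cc1ccc(-n2nncc2CN2C(=O)C3(C(C#N)=C(N)Oc4c(N)cc5nc6ccccc6nc5c43)c3ccccc32)cc1Cl` makes a change of the same kind, (3-chloro-4-methylphenyl in place of 2,4-dichlorophenyl on an aromatic nitrogen). The three measured steps bear on it only in that they all stay at the limit, so no step beyond the scatter is expected in this assay in either direction. Compound 4 is therefore expected to give 80000 nM, most likely reported as a limit again, within a range from 50000 nM to 200000 nM. The estimated step that the limit leaves unreadable from compound 3 to compound 4 is expected to be essentially none.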

Compound 4, half-maximal inhibitory concentration: > 50000 nM
Compound 4 ended at the assay's limit (the forecaster's own chance of this, stated with the estimate: 85%); the middle value is on the limit's open side.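

Compound 4 gives > 50000 nM in this assay, again a limit of the assay and not a number. Its steps from compound 1, compound 2 and compound 3 therefore cannot be read, and all four compounds stand at the same place: the limit of > 50000 nM in this assay, at which 4 of the 4 values shown sit.

The compounds shown leave open whether changing this aryl group moves the read-out in this assay at all.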